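Piperidine for morpholine on the aryl amide of compound 2

The source may report more compounds than this note shows. Statements on the series, on what has been measured and on what is new or still open speak of the compounds shown alone.

Measured compounds:
- compound 2, `NC(=O)Nc1sc(-c2ccc(C(=O)N3CCOCC3)cc2)cc1C(=O)N[C@H]1CCCNC1`: 610 nM
- compound 1, `NC(=O)Nc1sc(-c2ccccc2)cc1C(=O)NCC1CNCCO1`: "not determined" (no result reported)
- compound 3, `NC(=O)Nc1sc(-c2ccccc2)cc1C(=O)NC1CCCCC1`: "not determined" (no result reported)

Three compounds share a core, but only compound 2 carries a number in a functional assay on HT-29 cells (Homo sapiens) (on this read-out lower numbers stand for an effect already at smaller amounts and higher numbers for an effect only at larger amounts of compound), where compound 2 gives 610 nM. Among the compounds with values here, compound 1 and compound 3 were both tested in this assay without a reported result, so nothing can be said of how either stands against compound 2, and compound 2 is simply the one value in view.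

The unmeasured compound 4, `NC(=O)Nc1sc(-c2ccc(C(=O)N3CCCCC3)cc2)cc1C(=O)N[C@H]1CCCNC1`, differs from compound 2 in a single place: piperidin-1-yl in place of morpholin-4-yl on a carbonyl carbon. The two groups are the same size in heavy atoms; one ring oxygen is gone, and with it the sole hydrogen-bond acceptor of the leaving group.

Within the data shown here, no step between two measured compounds exists here to calibrate such a change, so the expectation rests on the change alone. Because compound 2 gives 610 nM and the swap is small, the step from compound 2 to compound 4 in this assay is expected to be a 1.2-fold lower number from compound 2 to compound 4 (0.09 log units; within the scatter), not beyond the usual scatter. Compound 4 is therefore estimated at 500 nM in this assay, with a range from 200 nM to 1500 nM.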

Compound 4, half-maximal effective concentration: 130 nM
Estimate against measurement, compound 4: 3.8-fold (0.59 log units) above; the whole stated range lies above it.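

In this assay, within the data shown here, replacing morpholin-4-yl with piperidin-1-yl on this carbonyl carbon gives a 4.7-fold lower number from compound 2 to compound 4 (0.67 log units; beyond the scatter), the first step and the first sign that the read-out responds to a change at this place. Both groups are six-membered non-aromatic rings of equal heavy-atom count, and the ring oxygen of morpholin-4-yl, its sole hydrogen-bond acceptor, is the difference between them, so a swap this small in atom count is enough to move the number beyond the usual scatter. Nothing in the data available here explains why the number moves with this swap.

On these data alone, it remains open whether the ring oxygen itself is what matters, and how groups such as pyrrolidin-1-yl, 4-methylpiperazin-1-yl or a dimethylamino group would stand on the same carbonyl carbon. Among these compounds, it is also open whether the same swap gives a step of like size when the rest of the molecule changes, since this single pair is the only comparison that can be read.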